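Swapping Fluoro for Bromo on the Pendant Phenyl

The source may hold more compounds than are shown below. What is called first, only, known or untested is meant among the compounds shown, and "the series" means these compounds.

Compound 1 `Cc1ccc(C(=O)Nc2cc(-c3ccccc3)nn2-c2ccccc2)cc1C` and compound 2 `O=C(Nc1cc(-c2ccccc2)nn1-c1ccccc1F)c1ccccc1` share a common core and were both run in a functional assay on cells for positive allosteric modulation of metabotropic glutamate receptor 5 (Rattus norvegicus), read by calcium flux; on this read-out higher numbers stand for an effect only at larger amounts of compound and lower numbers for an effect already at smaller amounts. In this assay compound 1 gives 20 nM, while compound 2 gives 104 nM, the higher of the two numbers, and the gap between the pair lies beyond the usual scatter. Compound 3 `O=C(Nc1cc(-c2ccccc2)nn1-c1ccccc1Br)c1ccccc1` has not yet been measured. It differs from compound 2 in one place: bromo in place of fluoro on an aromatic carbon, ortho to a large group. For the measured compounds named here, no measured pair in this set shows that change, so its size is unknown and can only be guessed. The step that the expectation below implies, a 1.2-fold higher number from compound 2 to compound 3 (0.06 log units; within the scatter), is expected to fall within the scatter, with no clear direction. For compound 3 the estimated value in this assay is 120 nM, with a range from 40 nM to 400 nM.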

Compound 3, half-maximal effective concentration: 200 nM
Compound 3: the middle estimate sits 1.7-fold (0.22 log units) below what was measured; the measured number falls inside the stated range.
By their numbers in this assay, from the lowest: compound 1; then compounds 2 and 3 (each within the scatter of the next).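

In this assay, for the compounds shown here, bromo in place of fluoro on an aromatic carbon, ortho to a large group, gives a 1.9-fold higher number from compound 2 to compound 3 (0.28 log units; within the scatter), the first reading of any change at this position. This step does not separate the two groups, so 2-fluorophenyl and 2-bromophenyl cannot be told apart here on these numbers, and the position carries either one with no clear shift in the read-out. No measurement at hand bears on why the two numbers lie this close.

On these data alone, whether a chloro, a methyl or a methoxy group at the same place would also stay within the scatter of compound 2 remains open. The compounds also leave open whether the swap from fluoro to bromo would give a similar step on a molecule carrying the two methyl groups of compound 1.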